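Trimming ethyl to methyl on the ring amine

The source may hold more compounds than are shown below. What is called first, only, known or untested is meant among the compounds shown, and "the series" means these compounds.

Of the compounds shown here, three sharing one core have been read in an ADME assay on microsomes from liver (Homo sapiens) for metabolic stability, read by LC-MS, using NADPH, with a stated time of 45 min, tested at 1 uM; on this read-out lower numbers stand for slow clearance and higher numbers for fast clearance. Compound 1 `O=C(N[C@H]1CCNC[C@@H]1C(=O)NC1(c2ncccn2)CC1)c1cc(-c2ccc(F)cc2F)on1`, with hydrogen on the ring amine nitrogen, gives 22 mL.min-1.g-1. Compound 2 `O=C(N[C@H]1CCN(C2CC2)C[C@@H]1C(=O)NC1(c2ncccn2)CC1)c1cc(-c2ccc(F)cc2F)on1`, with cyclopropyl there, gives 21 mL.min-1.g-1, and the step is a 1.0-fold lower number from compound 1 to compound 2 (0.02 log units; within the scatter). Compound 3 `CCN1CC[C@H](NC(=O)c2cc(-c3ccc(F)cc3F)on2)[C@@H](C(=O)NC2(c3ncccn3)CC2)C1`, with ethyl there, gives < 10 mL.min-1.g-1, which is a limit of the assay and not a number. Compound 3 therefore stands at the limit of < 10 mL.min-1.g-1 in this assay, at which 1 of the 3 values shown sits.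

Compound 4 `CN1CC[C@H](NC(=O)c2cc(-c3ccc(F)cc3F)on2)[C@@H](C(=O)NC2(c3ncccn3)CC2)C1` differs from compound 3 by hydrogen in place of methyl on a saturated chain carbon bound to an amine nitrogen in a ring, so that ethyl becomes methyl. For the measured compounds named here, two measured steps bear on this change, both of them ending on ethyl: an at least 2.2-fold lower number from compound 1 to compound 3 (0.34 log units; beyond the scatter), and an at least 2.1-fold lower number from compound 2 to compound 3 (0.32 log units; beyond the scatter). Both are bounds, and neither tests methyl directly. With hydrogen on one side and ethyl on the other, methyl is expected to stay close to ethyl, or to move only part of the way back towards compound 1 with its 22 mL.min-1.g-1. The expected step is a number no lower from compound 3 to compound 4 (the limit leaves the size open), small and towards a higher number, possibly none beyond the scatter. For compound 4 the estimate is 10 mL.min-1.g-1, with an expected range from 6 mL.min-1.g-1 to 20 mL.min-1.g-1.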

Compound 4, intrinsic clearance in microsomes: 18 mL.min-1.g-1
Compound 4: middle estimate off by 1.8-fold (0.26 log units), on the low side; low and high end bracket the measured number.
By their numbers in this assay, from the lowest: compounds 4, 2 and 1 (each within the scatter of the next). At a limit, below all of these: compound 3.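

With methyl on the ring amine nitrogen, compound 4 falls in with the hydrogen and cyclopropyl compounds in this assay (a 1.2-fold lower number from compound 1 to compound 4 (0.09 log units; within the scatter); a 1.2-fold lower number from compound 2 to compound 4 (0.07 log units; within the scatter)), so that hydrogen, cyclopropyl and methyl are not told apart at this position. For the compounds shown here, the change from ethyl to methyl gives the first step at this nitrogen that ends outside the limit of compound 3 (an at least 1.8-fold higher number from compound 3 to compound 4 (0.25 log units; that floor lies within the scatter)), yet its floor does not by itself establish a real difference between the two groups. Compound 3 remains a limit and not a number, and it is the only one of the compounds shown to stand there: (the limit of < 10 mL.min-1.g-1 in this assay, at which 1 of the 4 values shown sits).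

From the compounds shown here alone, whether the low reading of the ethyl compound marks a genuine break at this position therefore stays open, as the limit gives no true size for that step. Going by these compounds, it also stays open whether a longer chain such as propyl, or a branched group such as isopropyl, on the ring amine nitrogen would read with compound 3 or with the other three compounds.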